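A few compounds are considered here, and "the series" means these few. Any claim that something is new, unique, unknown or untested is made for them only; others in the source may bear on it.

Of the compounds shown here, three have been tested for inhibition of prostate cancer cell growth in a functional assay on DU-145 cells (Homo sapiens) for inhibition, read by WST assay, with a stated time of 3 days (a higher number here means a weaker inhibitor, a lower number a stronger inhibitor), and a fourth awaits measurement. Compound 1 `Cc1ncsc1-c1ccc(CNC(=O)[C@@H]2C[C@@H](O)CN2C(=O)[C@@H](NC(=O)COCCOCCn2cc(CCOc3ccc(Cl)cc3C(=O)Nc3ccc([N+](=O)[O-])cc3Cl)nn2)C(C)(C)C)cc1` is a large conjugate. In this assay compound 1 gives > 10000 nM, which is a limit of the assay and not a number. Compound 2 `O=C(O)COCCOCCOc1ccc(Cl)cc1C(=O)Nc1ccc([N+](=O)[O-])cc1Cl` is a smaller ether-linked carboxylic acid. In this assay compound 2 gives > 10000 nM, again a limit rather than a number. Compound 3 `CC(C)(C)OC(=O)COCCOCCn1cc(CCOc2ccc(Cl)cc2C(=O)Nc2ccc([N+](=O)[O-])cc2Cl)nn1` carries a tert-butyl ester at the end of a chain that runs through a triazole. In this assay compound 3 gives > 10000 nM, also a limit. Within the data shown here, compound 3 thus stands where every value so far stands, at the limit of > 10000 nM in this assay, at which 3 of the 3 values shown sit.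

Compound 4 `O=C(O)COCCOCCn1cc(CCOc2ccc(Cl)cc2C(=O)Nc2ccc([N+](=O)[O-])cc2Cl)nn1` differs from compound 3 by hydrogen in place of tert-butyl on an oxygen next to a carbonyl group. Among the measured compounds shown here, no step between two measured compounds is available to show what this change does. Compound 2 is likewise a carboxylic acid, and in this assay compound 2 gives > 10000 nM, a limit. The step from compound 3 to compound 4 is expected to be a step that the limit leaves unreadable from compound 3 to compound 4, nothing beyond the scatter. Compound 4 is therefore expected to give 20000 nM, in a range from 8000 nM to 60000 nM, most likely reported again only as a limit.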

Compound 4, half-maximal inhibitory concentration: > 10000 nM
Compound 4 gave a limit, no number; the forecaster's own chance of this, stated with the estimate: 90%; the middle value lies beyond the limit too.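

The step from compound 3 to compound 4 cannot be read, since neither compound gives a number in this assay, only a limit: the limit of > 10000 nM in this assay, at which 4 of the 4 values shown sit. The compounds shown leave open what the change from tert-butyl to hydrogen does to inhibition, and which change to these structures, if any, would give a measurable value.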